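Removing the propanoyl group from compound 1

The source may hold more compounds than are shown below. What is called first, only, known or untested is meant among the compounds shown, and "the series" means these compounds.

For the measured compounds named here, in a functional assay on Hs 683 cells (Homo sapiens) for inhibition, read by MTT assay, with a stated time of 72 h (a lower number here means a stronger inhibitor, a higher number a weaker inhibitor), compound 1 `CCC(=O)O[C@@H](/C(C)=C/[C@@H](C)c1oc(CC)c(C)c(=O)c1C)[C@H](C)[C@@H](OC(=O)CC(C)C)[C@@H](C)c1oc([C@@H](C)[C@@H](O)CC)c(C)c(=O)c1C` gives 13000 nM, the only actual number so far. Compound 2 `CCC(=O)[C@@H](C)c1oc([C@H](C)[C@@H]2O[C@](O)([C@@H](C)c3oc(CC)c(C)c(=O)c3C)[C@@H](C)[C@@H](O)[C@@H]2C)c(C)c(=O)c1C` is recorded at > 100000 nM, which is a limit of the assay and not a number. Compound 1 therefore has no second measured value to be ranked against, and its reading serves as the single anchor for what follows.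

The next compound to be tested is compound 3 `CCc1oc([C@H](C)/C=C(\C)[C@H](O)[C@H](C)[C@@H](OC(=O)CC(C)C)[C@@H](C)c2oc([C@@H](C)[C@@H](O)CC)c(C)c(=O)c2C)c(C)c(=O)c1C`. It differs from compound 1 in one place: hydrogen in place of propanoyl on an oxygen on a saturated carbon. This puts hydrogen in place of propanoyl on an oxygen on a saturated carbon, so that propanoyloxy becomes hydroxy, while the isovaleryl-free remainder of the comparison stays untouched.

Going by the values given here, no measured pair carries this change, so its size cannot be read from the data. The expectation therefore starts from compound 1 at 13000 nM and allows a wide margin. The estimated step of a 1.5-fold higher number from compound 1 to compound 3 (0.19 log units; within the scatter) is a modest one toward weaker inhibition in this assay, and it may not exceed the scatter. For compound 3 the expected value is 20000 nM, with an estimated range of 7000 nM to 60000 nM.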

Compound 3, half-maximal inhibitory concentration: > 100000 nM
Compound 3 gave a limit, no number; the forecaster's own chance of this, stated with the estimate: 15%; middle value at least 5.0-fold (0.69 log units) from the limit.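

In this assay, for the compounds shown here, replacing propanoyloxy with hydroxy on this saturated carbon gives the first measured step: an at least 7.6-fold higher number from compound 1 to compound 3 (0.88 log units; beyond the scatter). The step lies beyond the scatter, so at this position in the pair, the measurable activity of compound 1 depends on keeping the propanoyl group rather than hydrogen on the oxygen. The reading for compound 3 is a limit and not a number, so the step gives only a minimum size, and compound 3 now sits at the same limit as compound 2: the limit of > 100000 nM in this assay, at which 2 of the 3 values shown sit.

The compounds shown leave open whether the propanoyl group is specifically required, or whether an acetyl group, a longer acyl chain such as butanoyl, or an amine at this place would keep a measurable number, as compound 1 does at 13000 nM. They also leave open whether changing the isovaleryl group would give a step of similar size, which this pair cannot show.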